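Three Limits and a Nitrile Swap

The source may hold more compounds than are shown below. What is called first, only, known or untested is meant among the compounds shown, and "the series" means these compounds.

Measured in an ADME assay on Huh-7 cells (Homo sapiens) for cytotoxicity, with a stated time of 72 h; on this read-out higher numbers stand for lower toxicity in this test and lower numbers for higher toxicity in this test:
Compound 1 `CC(C)[C@H]1C(O)=C(C2=NS(=O)(=O)c3c(OCCC(N)=O)cccc32)C(=O)N1Cc1ccccc1`: > 33000 nM (a limit)
Compound 2 `CCOc1cccc2c1S(=O)(=O)N=C2C1=C(O)[C@H](CC(C)C)N(CCC(C)(C)C)C1=O`: > 33000 nM (a limit)
Compound 3 `CC(C)(C)[C@H]1C(O)=C(C2=NS(=O)(=O)c3c(OCC(N)=O)cccc32)C(=O)N1Cc1ccc(F)c(Cl)c1`: > 33000 nM (a limit)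

For compound 3, the reading of > 33000 nM is a limit of the assay and not a number. It gives no exact position, and compounds 1 and 2 offer no number either: the limit of > 33000 nM in this assay, at which 3 of the 3 values shown sit, is all that the series shows so far.

Compound 4 `CC(C)(C)[C@H]1C(O)=C(C2=NS(=O)(=O)c3c(OCC#N)cccc32)C(=O)N1Cc1ccc(F)c(Cl)c1` has cyano in place of carbamoyl on a saturated chain carbon bound to an oxygen on an aromatic ring and is otherwise identical to compound 3. Among the measured compounds shown here, no measured pair shows what a single change does in this assay, so no size can be taken from the data. The expectation is therefore no step beyond the scatter, with any real movement more likely downward from the limit. The estimated change is a number no higher from compound 3 to compound 4 (the limit leaves the size open) and would probably be reported as a limit again. Compound 4 is expected at 33000 nM, with an estimated range from 14000 nM to 33000 nM when it is measured.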

Compound 4, half-maximal cytotoxic concentration: > 33000 nM
Compound 4: only a limit was reported; the forecaster's own chance of this, stated with the estimate: 75%; the middle value sits exactly at the limit.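

Compound 3 and compound 4 both sit at a limit of the assay, so no step can be read for the change from carbamoyl to cyano. The compounds shown leave open how far any of them lies from that limit in this assay: the limit of > 33000 nM in this assay, at which 4 of the 4 values shown sit.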